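A few compounds are considered here, and "the series" means these few. Any claim that something is new, unique, unknown or untested is made for them only; others in the source may bear on it.

Compound 1 `Oc1ccc(-c2cc(-c3cccs3)nc(-c3ccccc3Cl)c2)cc1`, compound 2 `Oc1ccc(-c2cc(-c3ccc(Cl)cc3)nc(-c3cccs3)c2)cc1` and compound 3 `Oc1ccc(-c2cc(-c3ccc(Cl)cc3)nc(-c3ccsc3)c2)cc1` share a core carrying a 4-hydroxyphenyl group, a chlorophenyl group and a thiophen-2-yl or thiophen-3-yl group. In a functional assay on T47D cells (Homo sapiens) for cytotoxicity, read by CCK-8 assay and cell counting, with a stated time of 2 days (a higher number here means a weaker inhibitor, a lower number a stronger inhibitor), compound 1 gives 5870 nM, compound 2 gives 6450 nM and compound 3 gives 5490 nM. The change 2-chlorophenyl in place of 4-chlorophenyl on an aromatic carbon made a 1.1-fold lower number from compound 2 to compound 1 (0.04 log units; within the scatter). The cores of compound 2 and compound 3 differ by thiophen-3-yl in place of thiophen-2-yl on an aromatic carbon, which made a 1.2-fold lower number from compound 2 to compound 3 (0.07 log units; within the scatter). Compound 4 `Oc1ccc(-c2cc(-c3ccsc3)nc(-c3ccccc3Cl)c2)cc1` is not yet measured and differs from compound 3 by 2-chlorophenyl in place of 4-chlorophenyl on an aromatic carbon. This is the same kind of change as between compound 2 and compound 1, though the place differs: there the group stands meta to a thiophen-2-yl group, here meta to a thiophen-3-yl group. Because that earlier change gave a 1.1-fold lower number from compound 2 to compound 1 (0.04 log units; within the scatter), the expected step is a 1.1-fold lower number from compound 3 to compound 4 (0.04 log units; within the scatter). Compound 4 is therefore expected to give about 5000 nM in this assay, likely between 2500 nM and 10000 nM.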

Compound 4, half-maximal inhibitory concentration: 6110 nM
Compound 4: the middle estimate sits 1.2-fold (0.09 log units) below what was measured; measured number inside the range.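

In this assay, 2-chlorophenyl in place of 4-chlorophenyl gives a 1.1-fold higher number from compound 3 to compound 4 (0.05 log units; within the scatter) and the same change on the other core agrees with it: the same change on two cores in this assay, a 1.1-fold lower number (0.04 log units; within the scatter) from compound 2 to compound 1 and a 1.1-fold higher number (0.05 log units; within the scatter) from compound 3 to compound 4, 1.2-fold (0.09 log units) apart, within the scatter of two such steps

Thiophen-3-yl in place of thiophen-2-yl gives a 1.0-fold higher number from compound 1 to compound 4 (0.02 log units; within the scatter) and this change also agrees across the two cores: the same change on two cores in this assay, a 1.2-fold lower number (0.07 log units; within the scatter) from compound 2 to compound 3 and a 1.0-fold higher number (0.02 log units; within the scatter) from compound 1 to compound 4, 1.2-fold (0.09 log units) apart, within the scatter of two such steps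

Neither change moves the number beyond the usual scatter on either core, so this agreement shows only that both stay small here; it does not show that either change has a real effect, or that a larger effect would carry from one core to another.

All four compounds keep the 4-hydroxyphenyl group and a chlorine on the phenyl ring. Going by these compounds, what a methoxy group or an amine in place of that hydroxyl would do remains open, as does a fluorine in place of the chlorine.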